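Pyridin-2-yl replaces 4-chlorophenyl on the amide nitrogen

This account rests on a few compounds, and the source may have more. Where it says the series, first, only, none or still open, it means among the compounds named here.

Of the compounds shown here, three built on one shared core have been tested in an assay (strain Wistar) for inhibition of Hormone-sensitive lipase (Rattus norvegicus), read by spectrophotometry; a higher number here means a weaker inhibitor, a lower number a stronger inhibitor. Compound 1 `Cc1c(C(C)C)c(=O)on1C(=O)N(C)Cc1ccco1` gives 4 nM. Compound 2 `Cc1c(C(C)C)c(=O)on1C(=O)N(C)Cc1cccs1` gives 2 nM, and the step of a 2.0-fold lower number from compound 1 to compound 2 (0.30 log units; within the scatter) lies within the scatter. Compound 3 `Cc1c(C(C)C)c(=O)on1C(=O)N(C)c1ccc(Cl)cc1` gives 17 nM, the highest of the three numbers, with a 4.3-fold higher number from compound 1 to compound 3 (0.63 log units; beyond the scatter) and an 8.5-fold higher number from compound 2 to compound 3 (0.93 log units; beyond the scatter) both beyond the scatter. Compound 4 `Cc1c(C(C)C)c(=O)on1C(=O)N(C)c1ccccn1` differs from compound 3 in one place: pyridin-2-yl in place of 4-chlorophenyl on an amide-type nitrogen. For the measured compounds named here, the two measured steps that reach compound 3 both exchange a (furan-2-yl)methyl or a (thiophen-2-yl)methyl for the 4-chlorophenyl on the amide-type nitrogen; neither exchanges one aromatic ring bound directly to that nitrogen for another, so no measured step speaks directly to the change made in compound 4. Compound 4 is therefore expected to remain close to compound 3, with a step of a 1.2-fold higher number from compound 3 to compound 4 (0.07 log units; within the scatter) that may well fall within the scatter. In this assay compound 4 is estimated at 20 nM, with a range from 6 nM to 70 nM.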

Compound 4, half-maximal inhibitory concentration: 240 nM
The estimate for compound 4 lay 12-fold (1.08 log units) below the measured number; the measured number lies above the stated range.
By their numbers in this assay, from the lowest: compounds 2 and 1 (each within the scatter of the next); then compound 3; then compound 4.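

In this assay, the amide-type nitrogen proves sensitive to which ring is bound directly to it, not only to whether a saturated chain carbon carries that ring: a 14-fold higher number from compound 3 to compound 4 (1.15 log units; beyond the scatter), on exchanging 4-chlorophenyl, a ring of carbon only, for pyridin-2-yl, a ring with a hetero atom. Against the groups attached through a saturated chain carbon, the gaps are larger still, with a 60-fold higher number from compound 1 to compound 4 (1.78 log units; beyond the scatter) and a 120-fold higher number from compound 2 to compound 4 (2.08 log units; beyond the scatter), both exceeding every earlier step. No experimental evidence is available to explain this drop.

The compounds shown leave open whether the step follows the ring nitrogen or the missing chlorine: pyridin-2-yl differs from 4-chlorophenyl in both, and plain phenyl on the same nitrogen would separate the two. Also open, going by these compounds, is how (pyridin-2-yl)methyl would compare with the (furan-2-yl)methyl and (thiophen-2-yl)methyl groups.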